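Acylguanidine series: aryl substitution and exchanger inhibition

This account rests on a few compounds, and the source may have more. Where it says the series, first, only, none or still open, it means among the compounds named here.

Measured compounds:
compound 1, `CS(=O)(=O)c1cc(C(=O)N=C(N)N)c(Cl)cc1Cl`, 140 nM
compound 2, `Cc1c(C(=O)N=C(N)N)cc(S(C)(=O)=O)c(Cl)c1C`, 58 nM
compound 3, `CCC(C)c1cc(C)c(C(=O)N=C(N)N)cc1S(C)(=O)=O`, 8 nM

In a functional assay for inhibition of sodium/hydrogen exchanger (Oryctolagus cuniculus) (on this read-out higher numbers stand for weaker inhibition and lower numbers for stronger inhibition), compound 1 gives 140 nM and compound 2 gives 58 nM. Compound 3 gives 8 nM in this assay, the lowest of the three numbers; its gaps to compound 2 and to compound 1 both lie beyond the scatter, so compound 3 stands as the strongest inhibitor of the set. No pair among these three differs in one place only, so no single-point step can be read from them.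

Compound 4, `Cc1cc(Sc2ccc(Cl)cc2)c(S(C)(=O)=O)cc1C(=O)N=C(N)N`, has not yet been measured in this assay. It differs from compound 3 as follows:

(4-chlorophenyl)sulfanyl in place of sec-butyl on an aromatic carbon

The entering group is larger than the leaving one and adds a six-membered aromatic ring of carbon only, at the aromatic carbon ortho to a methylsulfonyl group. Among the compounds with values here, nothing among the measured compounds shows what such a replacement does in this assay, so the direction of the step is open. With compound 3 at 8 nM as the starting point, compound 4 is expected to show a step of a 1.9-fold higher number from compound 3 to compound 4 (0.27 log units; within the scatter), at most slightly weaker and possibly within the scatter. Compound 4 is estimated at 15 nM, with a range from 4 nM to 60 nM.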

Compound 4, half-maximal inhibitory concentration: 19 nM
Beside the measured number, compound 4's estimate is 1.3-fold (0.10 log units) below it, within the range that was stated.
By their numbers in this assay, from the lowest: compound 3; then compound 4; then compound 2; then compound 1.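

In this assay, within the data shown here, (4-chlorophenyl)sulfanyl in place of sec-butyl on the aromatic carbon ortho to a methylsulfonyl group gives a 2.4-fold higher number from compound 3 to compound 4 (0.38 log units; beyond the scatter), the first single-place step and the first direct reading of this position. The direction is toward weaker inhibition and the size is modest, yet the larger group with its six-membered aromatic ring is accepted at this carbon: compound 4 still gives 19 nM. No supporting data bear on why the number moves.

The change swaps the branched carbon chain for a sulfur atom, an aromatic ring and a chlorine all at once, so the compounds shown do not separate the contribution of each part to the step. Open questions are how a plain phenylsulfanyl, a phenoxy group or an amine such as piperidin-1-yl would read at the same carbon, and whether any group there would give a lower number than sec-butyl.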